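The source may hold more compounds than are shown below. What is called first, only, known or untested is meant among the compounds shown, and "the series" means these compounds.

Compound 1 `N=C(N)NCCC[C@H](NC(=O)CN(c1nc(Cl)nc2[nH]cnc12)C1CC1)C(=O)OCc1ccccc1` and compound 2 `O=C(OCc1ccccc1)[C@@H]1CCCN1C(=O)CN(c1nc(Cl)nc2[nH]cnc12)C1CC1` have both been tested in a functional assay on the whole organism (Tail, strain ICR) with Mus musculus as the target, in the tail flick test, with a stated time of 150 min, at a dose of 25 umol/kg by the oral route; on this read-out higher numbers stand for a stronger effect at the one dose given and lower numbers for a weaker effect. Compound 1 gives 6.12%, the lowest of the two numbers; compound 2 gives 31.1%, a number higher by more than the usual scatter. Compound 3 `CC(C)C[C@H](NC(=O)CN(c1nc(Cl)nc2[nH]cnc12)C1CC1)C(=O)OCc1ccccc1` has not yet been measured in this assay. It differs from compound 1 by a group of 3 heavy atoms (3 carbon; no ring) in place of a group of 6 heavy atoms (3 carbon, 3 nitrogen; no ring), on a saturated chain carbon, two bonds along the chain from an amide-type nitrogen and a carbonyl carbon. For the measured compounds named here, no measured pair shows a change of this kind, so the expectation rests only on the span between compound 1 and compound 2. A modest rise is expected, a number 11.9 percentage points higher from compound 1 to compound 3 (beyond the scatter), still within the range those two compounds set. Compound 3 is thus estimated at 18%, with a range from 4% to 40%.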

Compound 3, a percentage reported as activity, at one dose (the size of the read-out at that dose, not a potency): 5.26%
Estimate against measurement, compound 3: 12.7 percentage points above, and the stated range covers the measured number.
By their numbers in this assay, from the lowest: compounds 3 and 1 (each within the scatter of the next); then compound 2.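

In this assay, isopropyl in place of the group of 6 heavy atoms on this saturated chain carbon gives a number 0.9 percentage points lower from compound 1 to compound 3 (within the scatter), so compound 1 and compound 3 cannot be told apart at this one dose. At this position, then, the read-out does not separate a chain end with 3 nitrogen atoms and 3 hydrogen-bond donors from an isopropyl group with neither. No measurement at hand gives a reason for this. As far as these compounds go, whether an amine, a carboxylic acid or a longer chain at this position would read any differently stays open. Also open, from the compounds shown here alone, is whether other doses would separate compound 1 and compound 3.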